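A few compounds are considered here, and "the series" means these few. Any claim that something is new, unique, unknown or untested is made for them only; others in the source may bear on it.

Measured so far:
compound 1 `C=C1C(=O)[C@@]23C(=O)OC[C@]4([C@@H](OC(C)=O)CCC(C)(C)[C@H]4C=O)[C@@H]2CC[C@H]1[C@H]3OC(=O)c1ccc(OC)cc1` — 2530 nM
compound 2 `C=C1C(=O)[C@@]23C(=O)OC[C@]4([C@@H](OC(C)=O)CCC(C)(C)[C@H]4C=O)[C@@H]2CC[C@H]1[C@H]3OC(=O)c1ccc(C(F)(F)F)cc1` — 5540 nM

Among the measured compounds shown here, in a functional assay on MGC-803 cells (Homo sapiens) for inhibition, read by MTT assay (on this read-out lower numbers stand for stronger inhibition and higher numbers for weaker inhibition), compound 2 holds the higher of the two numbers, with compound 1 its only neighbour, reached by a 2.2-fold higher number from compound 1 to compound 2 (0.34 log units; beyond the scatter). Compound 3 `C=C1C(=O)[C@@]23C(=O)OC[C@]4([C@@H](OC(C)=O)CCC(C)(C)[C@H]4C=O)[C@@H]2CC[C@H]1[C@H]3OC(=O)c1ccccc1` differs from compound 2 in one place: hydrogen in place of trifluoromethyl on an aromatic carbon. For the measured compounds named here, no measured pair shows this exact change; the single step from compound 1 to compound 2 is the only guide, and it was modest. For compound 3 a modest step toward a lower number is therefore expected, roughly a 1.6-fold lower number from compound 2 to compound 3 (0.20 log units; within the scatter). Compound 3 is estimated at 3500 nM, within 1500 nM to 8000 nM.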

Compound 3, half-maximal inhibitory concentration: 2180 nM
For compound 3 the middle estimate is 1.6-fold (0.21 log units) above the measured one; measured number inside the range.
By their numbers in this assay, from the lowest: compounds 3 and 1 (each within the scatter of the next); then compound 2.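

In this assay, hydrogen in place of trifluoromethyl gives a 2.5-fold lower number from compound 2 to compound 3 (0.41 log units; beyond the scatter), so the higher number of compound 2 goes with the trifluoromethyl group rather than with the shared core. Hydrogen in place of methoxy gives a 1.2-fold lower number from compound 1 to compound 3 (0.06 log units; within the scatter), so at this place on the aromatic ring methoxy and hydrogen cannot be told apart, and only trifluoromethyl stands off from them. No measurement at hand explains this difference. As far as these compounds go, whether an amine or a carboxylic acid at this place would read like hydrogen or like trifluoromethyl stays open, as does the effect of a longer chain in place of benzoyl.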